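A few compounds are considered here, and "the series" means these few. Any claim that something is new, unique, unknown or untested is made for them only; others in the source may bear on it.

Measured compounds:
- compound 1, `CCCCCCn1nnc2c1CCN(c1ccccc1)C2`: > 100000 nM
- compound 2, `Fc1ccc(Cn2nnc3c2CCN(c2ccc(C(F)(F)F)cc2)C3)cc1`: 100000 nM
- compound 3, `CCCCCCn1nnc2c1CCN(c1ccc(C(F)(F)F)cc1)C2`: > 100000 nM

In an ADME assay on HEL cells (Homo sapiens) for cytotoxicity, read by microscopy, with a stated time of 3 days (on this read-out lower numbers stand for higher toxicity in this test and higher numbers for lower toxicity in this test), compound 3 gives only a limit, > 100000 nM, not a number. Compound 1 likewise gives a limit, > 100000 nM. Compound 2 gives a number, 100000 nM. So compound 3 stands at the edge of what this assay can report, and a further shown value sits there too (the limit of > 100000 nM in this assay, at which 2 of the 3 values shown sit).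

The unmeasured compound 4, `CCCCCCn1nnc2c1CCN(c1ccc(F)cc1)C2`, differs from compound 3 in one place: fluoro in place of trifluoromethyl on an aromatic carbon.

Among the measured compounds shown here, two measured steps touch compound 3. The step that the two limits leave unreadable from compound 1 to compound 3 lies between two limits, so its size cannot be read. The step of a number no lower from compound 2 to compound 3 (the limit leaves the size open) ends at a limit and is only known to be no lower. For the measured compounds named here, neither step shows a change beyond the usual scatter, and no measured compound carries fluoro at this place. The expected step of a number no higher from compound 3 to compound 4 (the limit leaves the size open) is therefore none beyond the scatter. Compound 4 is estimated at 100000 nM, between 50000 nM and 200000 nM, most likely again reported as a limit.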

Compound 4, minimum cytotoxic concentration: > 100000 nM
Compound 4: no number, only a limit; the forecaster's own chance of this, stated with the estimate: 70%; the middle value lies on the limit itself.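

In this assay compound 4 gives only a limit, > 100000 nM. Among the compounds shown here, compound 1 and compound 3 also give only limits, so no step from either of them to compound 4 can be read. From the compounds shown here alone, whether hydrogen, trifluoromethyl and fluoro at this place differ at all in cytotoxicity stays open.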